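Replacing a trifluorophenyl amine with a methylphenyl amine

The compounds below may be only part of what the source reports. "The series", "measured", "known", "first", "only" and "open" are said of these compounds alone.

Of the compounds shown here, two sharing one core have been tested. Compound 1 `COc1cc2ncnc(Nc3cccc(Cl)c3)c2cc1OCCCCC(=O)Nc1ccc(S(N)(=O)=O)cc1` in a functional assay on A549 cells (Homo sapiens) for antiproliferative activity, read by MTT assay, with a stated time of 72 h (a lower number here means a stronger inhibitor, a higher number a weaker inhibitor), gives 11200 nM. Compound 2 `COc1cc2ncnc(Nc3cc(F)c(F)c(F)c3)c2cc1OCCCCC(=O)Nc1ccc(S(N)(=O)=O)cc1` carries a 3,4,5-trifluorophenyl on the same nitrogen. In this assay compound 2 reaches only the limit of > 40000 nM, so its standing is known only as a bound and not as a number; it sits at the limit of > 40000 nM in this assay, at which 1 of the 2 values shown sits. For the measured compounds named here, the single measured step, an at least 3.5-fold higher number from compound 1 to compound 2 (0.55 log units; beyond the scatter), is the only comparison available.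

Compound 3 `COc1cc2ncnc(Nc3ccc(C)cc3)c2cc1OCCCCC(=O)Nc1ccc(S(N)(=O)=O)cc1` is not yet measured. It differs from compound 2 as follows: 4-methylphenyl in place of 3,4,5-trifluorophenyl on a nitrogen on an aromatic ring. Going by the values given here, no measured step covers this exact exchange; the step from compound 1 to compound 2 shows only that the trifluorophenyl amine gave the weaker result. On that basis compound 3 is expected to give a lower number than the bound of compound 2, a step of about an at least 2.0-fold lower number from compound 2 to compound 3 (0.30 log units; that floor lies within the scatter). The estimate for compound 3 in this assay is 20000 nM, within a range of 6000 nM to 60000 nM.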

Compound 3, half-maximal inhibitory concentration: > 40000 nM
Compound 3 gave a limit, no number; the forecaster's own chance of this, stated with the estimate: 30%; middle value at least 2.0-fold (0.30 log units) away from the limit.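

In this assay compound 3 gives > 40000 nM as a limit of the assay and not a number, so the step between compound 2 and compound 3 cannot be read. The new finding is that the shortfall is not confined to the fluorinated group: 4-methylphenyl in place of 3-chlorophenyl on this nitrogen gives an at least 3.5-fold higher number from compound 1 to compound 3 (0.55 log units; beyond the scatter) and so, with no fluorine present, also falls short of compound 1. Compound 1 is now the only one of the three with a measured number, while the other two stop at the same limit: the limit of > 40000 nM in this assay, at which 2 of the 3 values shown sit.

From the compounds shown here alone, how far compound 2 and compound 3 lie from each other stays open. So does whether a bromophenyl or a methoxyphenyl on the same nitrogen would give a number in this assay at all.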